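This account rests on a few compounds, and the source may have more. Where it says the series, first, only, none or still open, it means among the compounds named here.

Measured compounds:
compound 1, `O/N=C1\CCCc2onc(-c3cccc(F)c3)c21`, gives > 25000 nM in a functional assay on MCF7 cells (Homo sapiens) for antiproliferative activity, read by MTT assay, with a stated time of 72 h; a lower number here means a stronger inhibitor, a higher number a weaker inhibitor.
compound 2, `O=C(Nc1ccccc1C(=O)O/N=C1\CCCc2onc(-c3ccc(F)cc3)c21)c1cccc(F)c1`, gives > 25000 nM in this assay.
compound 3, `O=C(Nc1cccc(C(=O)O/N=C2\CCCc3onc(-c4cccc(F)c4)c32)c1)c1cccc(F)c1`, gives 4700 nM in this assay.

Compound 1 carries the free oxime and its result is a limit of this assay, not a number. Compound 2 carries an ester of a fluorobenzoyl-amino benzoic acid, and its result is also a limit. Going by the values given here, compound 3 carries a related ester, placed differently on the benzoic acid, and it is the only compound of the three with an actual number in this assay, the other two sitting at the limit of > 25000 nM in this assay, at which 2 of the 3 values shown sit. Among the compounds with values here, compound 3 is therefore the only point from which a comparison can start, and no step between two measured compounds is available to show how a change in one place moves the number.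

Compound 4, `O=C(Nc1cccc(C(=O)O/N=C2\CCCc3onc(-c4ccccc4F)c32)c1)c1cccc(F)c1`, differs from compound 3 in one place: 2-fluorophenyl in place of 3-fluorophenyl on an aromatic carbon. Within the data shown here, with no measured step to lean on, the change from compound 3 to compound 4 is expected to stay within the usual scatter, in no particular direction. Compound 4 is thus estimated at 6000 nM, with a range from 2000 nM to 25000 nM, a step of a 1.3-fold higher number from compound 3 to compound 4 (0.11 log units; within the scatter) that carries a real chance of the assay reporting only a limit.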

Compound 4, half-maximal inhibitory concentration: > 25000 nM
Compound 4: a limit, no number; the forecaster's own chance of this, stated with the estimate: 30%; at least 4.1-fold (0.61 log units) between middle value and limit.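

Going by these compounds alone, until now no two measured compounds differed in just one place, and 2-fluorophenyl in place of 3-fluorophenyl supplies the first such comparison: in this assay, this change gives an at least 5.3-fold higher number from compound 3 to compound 4 (0.72 log units; beyond the scatter). On these data alone, the result for compound 4 is a limit of the assay and not a number, so the full size of this step remains unknown. The two groups hold the same atoms, so on this aromatic carbon, next to the ring nitrogen, where the fluorine sits on the phenyl ring is enough to separate a measurable result from a limit, and compound 3 remains the only compound with a number: the limit of > 25000 nM in this assay, at which 3 of the 4 values shown sit.

The compounds shown leave open whether the fluorine is needed at all, since neither a plain phenyl nor a phenyl carrying a chlorine, a methoxy group or an amine appears at this place. With a single readable step, they also cannot tell why the placement of the fluorine matters, or whether a similar change elsewhere on the molecule, such as on the fluorobenzoyl group, would matter as much.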